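The source may report more compounds than this note shows. Statements on the series, on what has been measured and on what is new or still open speak of the compounds shown alone.

Working notes on the series, read in a functional assay on the whole organism with Scenedesmus acutus as the target, with a stated time of 20 h; a lower number here means a stronger inhibitor, a higher number a weaker inhibitor. Compound 1 (`O=C(O)c1cc(N2C(=O)C3=C(CCCC3)C2=O)ccc1Cl`) gives > 100000 nM, which is a limit of the assay. Among the compounds with values here, compound 2 (`CCOC(=O)c1cc(N2C(=O)C3=C(CCCC3)C2=O)ccc1Cl`) gives 2140 nM, the only actual number so far. Compound 3 (`CC(C)(C)OC(=O)c1cc(N2C(=O)C3=C(CCCC3)C2=O)ccc1Cl`) stands at > 100000 nM, which is also only a limit.

Compound 4 (`C#CCOc1cc(N2C(=O)C3=C(CCCC3)C2=O)ccc1Cl`) carries propargyloxy in place of tert-butoxycarbonyl on an aromatic carbon, ortho to a chloro group: propargyloxy in place of tert-butoxycarbonyl on an aromatic carbon.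

The measured steps bearing on this all change the same substituent. Ethyl in place of hydrogen gave an at least 46-fold lower number from compound 1 to compound 2 (1.66 log units; beyond the scatter), and tert-butyl in place of ethyl gave an at least 46-fold higher number from compound 2 to compound 3 (1.66 log units; beyond the scatter). Within the data shown here, both are large, so this assay responds strongly to changes here, although no measured step removes the carbonyl group. Compound 2 at 2140 nM is the only numerical anchor, so a return towards that level is the working expectation. A real chance remains that compound 4 stays as weak as compound 3.

The expected change is an at least 33-fold lower number from compound 3 to compound 4 (1.52 log units; beyond the scatter). For compound 4 the estimated value is 3000 nM, with an expected range of 300 nM to 60000 nM.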

Compound 4, half-maximal inhibitory concentration: 537 nM
Estimate against measurement, compound 4: 5.6-fold (0.75 log units) above, within the range that was stated.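

In this assay, propargyloxy in place of ethoxycarbonyl gives a 4.0-fold lower number from compound 2 to compound 4 (0.60 log units; beyond the scatter), so a carbonyl group on this aromatic carbon is not needed for inhibition within these compounds. Propargyloxy in place of tert-butoxycarbonyl gives an at least 180-fold lower number from compound 3 to compound 4 (2.27 log units; beyond the scatter), and propargyloxy in place of carboxy gives an at least 180-fold lower number from compound 1 to compound 4 (2.27 log units; beyond the scatter), both steps starting from a limit: the limit of > 100000 nM in this assay, at which 2 of the 4 values shown sit.
Within the data shown here, compound 4 is the strongest of the four compounds and the only one without a carbonyl group at this position.

The compounds shown do not separate the contribution of the triple bond from that of the ether oxygen, which a propoxy chain on the same aromatic carbon would do. Going by these compounds, how an amine or a longer alkynyloxy chain would read at this position also remains open.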